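The source may hold more compounds than are shown below. What is called first, only, known or untested is meant among the compounds shown, and "the series" means these compounds.

Compound 1 `c1csc(-c2ccccc2NCC2=NCCN2)c1`: 5.75 nM
Compound 2 `Cc1ccsc1-c1ccccc1NCC1=NCCN1`: 112 nM
Compound 3 `CO/N=C(\C)c1ccccc1NCC1=NCCN1`: < 5020 nM

Three compounds built on one shared core were tested in a functional assay for activation of Alpha-1B adrenergic receptor (Homo sapiens), read by calcium flux; on this read-out lower numbers stand for an effect already at smaller amounts and higher numbers for an effect only at larger amounts of compound. Among the two readable numbers, compound 1 gives the lower one, and compound 2 follows with a 19-fold higher number from compound 1 to compound 2 (1.29 log units; beyond the scatter). For compound 3 only a limit of the assay is known, (the limit of < 5020 nM in this assay, at which 1 of the 3 values shown sits). Compound 4 `CC/C(=N/OC)c1ccccc1NCC1=NCCN1` is not yet measured; it differs from compound 1 in that (a group of 6 heavy atoms (4 carbon, 1 nitrogen, 1 oxygen; no ring) in place of a group of 5 heavy atoms (4 carbon, 1 sulfur; one five-membered aromatic ring with 1 hetero atom), on an aromatic carbon). Among the measured compounds shown here, the steps that bear on this change are a step that the limit leaves unreadable from compound 1 to compound 3 and a step that the limit leaves unreadable from compound 2 to compound 3, neither of which gives a size. For the measured compounds named here, the one readable step, a 19-fold higher number from compound 1 to compound 2 (1.29 log units; beyond the scatter), shows that even a small change on this ring can cost much. A clearly weaker effect is therefore expected, a 52-fold higher number from compound 1 to compound 4 (1.72 log units; beyond the scatter). Compound 4 is estimated at 300 nM, within 30 nM to 3000 nM.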

Compound 4, half-maximal effective concentration: < 5020 nM
Compound 4: no number, only a limit; the forecaster's own chance of this, stated with the estimate: 20%; the middle value is on the limit's open side.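

Compound 4 gives only a limit of the assay, so no step linking it to compound 1, compound 2 or compound 3 can be read: the limit of < 5020 nM in this assay, at which 2 of the 4 values shown sit.

The compounds shown leave open what actual numbers compound 3 and compound 4 would give in this assay.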